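Swapping morpholin-4-yl for 3-isopropoxypropyl on an amide-type nitrogen

The source may hold more compounds than are shown below. What is called first, only, known or untested is meant among the compounds shown, and "the series" means these compounds.

Compound 1 `COc1cccc(OC)c1C(=O)Nc1c[nH]nc1C(=O)NC1CCN(Cc2ccccc2)C1`: 38000 nM
Compound 2 `COc1cccc(OC)c1C(=O)Nc1c[nH]nc1C(=O)NN1CCOCC1`: > 50000 nM

In an ADME assay on MRC5 cells (Homo sapiens) for inhibition, with a stated time of 72 h (on this read-out higher numbers stand for an effect only at larger amounts of compound and lower numbers for an effect already at smaller amounts), compound 2 gives > 50000 nM, which is a limit of the assay and not a number.

Compound 3 `COc1cccc(OC)c1C(=O)Nc1c[nH]nc1C(=O)NCCCOC(C)C` keeps the shared core and changes one group, 3-isopropoxypropyl in place of morpholin-4-yl on an amide-type nitrogen.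

Compound 1, with yet another group on that amide, gives 38000 nM, so a large change in this assay seems unlikely. The expected result is no shift beyond the usual scatter, and the estimated change is an at least 1.1-fold lower number from compound 2 to compound 3 (0.04 log units; that floor lies within the scatter). Compound 3 is expected at 45000 nM, with an estimated range from 20000 nM to 90000 nM.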

Compound 3, half-maximal effective concentration: > 50000 nM
Compound 3: no number, only a limit; the forecaster's own chance of this, stated with the estimate: 60%; middle value at least 1.1-fold (0.04 log units) from the limit.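

In this assay compound 2 gives > 50000 nM, a limit of the assay and not a number. Going by these compounds alone, compound 3 gives > 50000 nM, also a limit, so no step between these two compounds can be read. Going by these compounds, whether 3-isopropoxypropyl and morpholin-4-yl on that amide nitrogen differ at all in this read-out stays open.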